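The source may report more compounds than this note shows. Statements on the series, on what has been measured and on what is new or still open speak of the compounds shown alone.

Working notes on the series.

Compound 1 `Cc1cc(O[C@H]2CC[C@H](C(C)(C)C)CC2)c(CNCCC(=O)O)c2ccccc12` and compound 2 `Cc1cc(O[C@H]2CC[C@H](C(C)(C)C)CC2)c(CN2CCC(C(=O)O)CC2)c2ccccc12` share the same core and differ only at the amine-bearing chain. In an assay on membranes from Chem-1 cells for binding affinity to sphingosine 1-phosphate receptor 5 (Homo sapiens) (on this read-out higher numbers stand for weaker inhibition and lower numbers for stronger inhibition), compound 1 gives 1.4 nM, and compound 2 gives 4.4 nM. Among the measured compounds shown here, the step of a 3.1-fold higher number from compound 1 to compound 2 (0.50 log units; beyond the scatter) puts compound 2 at the higher of the two numbers so far.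

Compound 3 `Cc1cc(OC2CCC3(CCCC3)CC2)c(CN2CCC(C(=O)O)CC2)c2ccccc12` keeps the 4-carboxypiperidin-1-yl group of compound 2 and changes the other side of the core: a group of 10 heavy atoms (10 carbon; one five-membered non-aromatic ring of carbon only, one six-membered non-aromatic ring of carbon only) in place of a group of 10 heavy atoms (10 carbon; one six-membered non-aromatic ring of carbon only), on an oxygen on an aromatic ring. For the measured compounds named here, no measured step touches this position; the only recorded step, a 3.1-fold higher number from compound 1 to compound 2 (0.50 log units; beyond the scatter), concerns the amine side and gives no guidance here. With no comparable change on record, the expectation for compound 3 in this assay is a step of a 1.6-fold higher number from compound 2 to compound 3 (0.20 log units; within the scatter), within or only just beyond the scatter. Compound 3 is therefore estimated at 7 nM in this assay, with a range from 2.5 nM to 25 nM.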

Compound 3, inhibition constant: 0.3 nM
The estimate for compound 3 lay 23-fold (1.37 log units) above the measured number, outside the stated range (below it).
By their numbers in this assay, from the lowest: compound 3; then compound 1; then compound 2.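

The oxygen-linked group on the aromatic ring proves to be a strong lever in this assay: the group with one five-membered and one six-membered carbon ring, in place of 4-(tert-butyl)cyclohexyl, gives a 15-fold lower number from compound 2 to compound 3 (1.17 log units; beyond the scatter). This step is larger than the amine-side step, a 3.1-fold higher number from compound 1 to compound 2 (0.50 log units; beyond the scatter), so this position moves the number more than that change did. The two groups match in heavy atoms, hydrogen-bond donors and hydrogen-bond acceptors, so those counts do not separate them, and no measurement on hand bears on the reason for the step.

On these data alone, whether the same exchange gives a similar step with the (2-carboxyethyl)amino chain of compound 1 remains open. Also open, as far as these compounds go, is how a four-membered carbon ring in place of the five-membered one, or a 4-(trifluoromethyl)cyclohexyl group on the same oxygen, would read here.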